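This account rests on a few compounds, and the source may have more. Where it says the series, first, only, none or still open, it means among the compounds named here.

Measured compounds:
compound 1, `C=CCn1c(=O)/c(=C\c2cccc(Cl)c2Cl)[nH]c(=O)/c1=C\c1ccccc1OC`, 1200 nM
compound 2, `C=CCn1c(=O)/c(=C\c2ccc(F)c(Br)c2)[nH]c(=O)/c1=C\c1ccccc1OC`, "not active" (no number reported)

In a functional assay on Huh-7 cells (Homo sapiens) for cytotoxicity, read by CCK-8 assay, with a stated time of 72 h (on this read-out higher numbers stand for weaker inhibition and lower numbers for stronger inhibition), compound 1 gives 1200 nM, while compound 2 was reported as "not active" (no number reported), so no single number places compound 2 on this scale. Compound 3, `C=CCn1c(=O)/c(=C\c2cccc(C)c2)[nH]c(=O)/c1=C\c1ccccc1OC`, is not yet measured; it differs from compound 2 by 3-methylphenyl in place of 3-bromo-4-fluorophenyl on a double-bonded chain carbon bound to an aromatic carbon. Within the data shown here, with no measured step of this kind to lean on, the direction and size of any shift in this assay are open. Compound 3 is expected to show weak inhibition, estimated at 4000 nM within a range of 1000 nM to 20000 nM.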

Compound 3, half-maximal inhibitory concentration: 21400 nM
For compound 3 the middle estimate is 5.4-fold (0.73 log units) below the measured one; the whole stated range lies below it.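

In this assay, the group on this double-bonded chain carbon strongly affects the read-out: 3-methylphenyl in place of 2,3-dichlorophenyl gives an 18-fold higher number from compound 1 to compound 3 (1.25 log units; beyond the scatter). Compound 2 has no number, and its step to compound 3 cannot be read. Nothing available explains the shift. Still open, going by these compounds, is how a group with one chlorine, such as 3-chlorophenyl, would compare, which could help separate the contributions of the two chlorines. Also open, on these data alone, is how a phenyl group carrying an amine or a carboxylic acid would read at this place.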